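This account rests on a few compounds, and the source may have more. Where it says the series, first, only, none or still open, it means among the compounds named here.

Measured in an ADME assay on Vero 76 cells (Chlorocebus sabaeus) for cytotoxicity, read by MTT assay, with a stated time of 96 h; on this read-out lower numbers stand for higher toxicity in this test and higher numbers for lower toxicity in this test:
compound 1 `Cc1ccc(C2CC(c3ccc(OCc4ccccc4)cc3)=NN2c2ccc(S(N)(=O)=O)cc2)cc1`: 100000 nM
compound 2 `NS(=O)(=O)c1ccc(N2N=C(c3ccc(Oc4ccccc4)cc3)CC2c2cccc(F)c2)cc1`: 28000 nM

Compound 2, at 28000 nM, holds the lower of the two numbers, and the gap to compound 1, at 100000 nM, lies beyond the scatter. The next entry is compound 3 `NS(=O)(=O)c1ccc(N2N=C(c3ccc(OCc4ccccc4)cc3)CC2c2cccc(F)c2)cc1`, which departs from compound 2 in one place: benzyl in place of phenyl on an oxygen on an aromatic ring. In words, this is benzyl in place of phenyl on an oxygen on an aromatic ring. Among the measured compounds shown here, no measured pair shows this change alone. Compound 1 also carries benzyloxy and gives 100000 nM, but it differs from compound 3 elsewhere, so it is only a weak guide. A modest rise in this assay is therefore expected, with an estimated 1.6-fold higher number from compound 2 to compound 3 (0.21 log units; within the scatter). The estimate for compound 3 is 45000 nM, with an expected range of 17000 nM to 100000 nM.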

Compound 3, half-maximal cytotoxic concentration: 90000 nM
For compound 3 the middle estimate is 2.0-fold (0.30 log units) below the measured one, and the stated range covers the measured number.
By their numbers in this assay, from the lowest: compound 2; then compounds 3 and 1 (each within the scatter of the next).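

In this assay, phenoxy to benzyloxy now has a direct reading, with 3-fluorophenyl held constant on the saturated ring carbon: benzyl in place of phenyl on an oxygen on an aromatic ring gives a step beyond the scatter (a 3.2-fold higher number from compound 2 to compound 3 (0.51 log units; beyond the scatter)). With benzyloxy held constant, 3-fluorophenyl in place of 4-methylphenyl on a saturated ring carbon stays within the scatter (a 1.1-fold lower number from compound 1 to compound 3 (0.05 log units; within the scatter)), so this pair does not separate those two groups. Nothing measured here explains the phenoxy to benzyloxy step.

As far as these compounds go, the step rests on a single pair, so it remains open whether it holds with 4-methylphenyl on the saturated ring carbon. Also open, from the compounds shown here alone, is how phenethyl or aminomethyl in place of benzyl on an oxygen on an aromatic ring would read in this assay here.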